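The source may hold more compounds than are shown below. What is called first, only, known or untested is meant among the compounds shown, and "the series" means these compounds.

Measured so far in an assay on isolated protein for inhibition of Gonadotropin-releasing hormone receptor (Homo sapiens); on this read-out higher numbers stand for weaker inhibition and lower numbers for stronger inhibition:
compound 1, `Cc1cccc(CSc2nc3cc(NC(=O)C4CC4)ccc3n2C(C)C)c1`: 6500 nM
compound 2, `COc1ccc(C#N)cc1CSc1nc2cc(NC(=O)C3CC3)ccc2n1C(C)C`: 570 nM
compound 3, `CCCCCn1c(SCc2cc([N+](=O)[O-])ccc2OC)nc2cc(NC(=O)NC(C)(C)C)ccc21`: 210 nM

Compound 3 carries the lowest number of the three in this assay. Compound 2 is nearest to it and compound 1 furthest; both gaps lie beyond the scatter, so compound 3 is the strongest inhibitor among the measured compounds. Among the measured compounds shown here, the only single-place step measured so far is an 11-fold lower number from compound 1 to compound 2 (1.06 log units; beyond the scatter); it concerns the group on the saturated chain carbon bound to the sulfur, not the group on the aromatic nitrogen.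

Compound 4, `COc1ccc([N+](=O)[O-])cc1CSc1nc2cc(NC(=O)NC(C)(C)C)ccc2n1C(C)C`, is the next compound to be measured. Relative to compound 3 it differs as follows: isopropyl in place of pentyl on an aromatic nitrogen. For the measured compounds named here, no measured step touches the aromatic nitrogen alone. Compound 2 and compound 3 differ there, but also in two further places at once, so their values give nothing that can be separated out for this change. Going by the values given here, with no direct precedent, the expectation is a step within the scatter in this assay, in either direction, so the expected step is a 1.4-fold higher number from compound 3 to compound 4 (0.15 log units; within the scatter). Compound 4 is therefore estimated at 300 nM in this assay, within a range from 100 nM to 900 nM.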

Compound 4, half-maximal inhibitory concentration: 62 nM
Estimate against measurement, compound 4: 4.8-fold (0.68 log units) above, outside the stated range (below it).
By their numbers in this assay, from the lowest: compound 4; then compound 3; then compound 2; then compound 1.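

In this assay, the group on the aromatic nitrogen turns out to matter on its own: isopropyl in place of pentyl gives a 3.4-fold lower number from compound 3 to compound 4 (0.53 log units; beyond the scatter), with the rest of the structure unchanged. Among the compounds shown here, this is the first reading of this position free of changes elsewhere, and it shows that the pentyl chain is not required for a number in this range, since the smaller isopropyl group, with 3 heavy atoms against 5, goes with a lower number. Both groups are plain carbon groups without a ring, hydrogen-bond donors, hydrogen-bond acceptors or net charge, but nothing available explains why the number moves with this change.

On these data alone, two groups at one position define no trend, so how methyl, ethyl, cyclopentyl or a pentyl chain ending in an amine would read on this nitrogen remains open. Also open, as far as these compounds go, is whether the step from pentyl to isopropyl carries over to compounds with other groups elsewhere, such as the nitrile in place of the nitro group or the cyclopropyl amide in place of the tert-butyl urea.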